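Ethoxycarbonyl for hydroxymethyl: expected step in cytotoxicity

A few compounds are considered here, and "the series" means these few. Any claim that something is new, unique, unknown or untested is made for them only; others in the source may bear on it.

In an ADME assay on CHO-K1 cells (Cricetulus griseus) for cytotoxicity, read by MTT assay, with a stated time of 24 h (on this read-out lower numbers stand for higher toxicity in this test and higher numbers for lower toxicity in this test), compound 1 (`OCc1ccc(NC(=S)Nc2ccc3[nH]ccc3c2)cc1`) gives 1080000 nM as the highest of three numbers, against 36000 nM for compound 2 (`S=C(Nc1ccc(Oc2ccccc2)cc1)Nc1ccc2[nH]ccc2c1`) and 20000 nM for compound 3 (`O=C(c1ccccc1)c1ccc(NC(=S)Nc2ccc3[nH]ccc3c2)cc1`). Compound 4 (`CCOC(=O)c1ccc(NC(=S)Nc2ccc3[nH]ccc3c2)cc1`) carries ethoxycarbonyl in place of hydroxymethyl on an aromatic carbon. Two measured replacements of the same hydroxymethyl bear on this: phenoxy (a 30-fold lower number from compound 1 to compound 2 (1.48 log units; beyond the scatter)) and benzoyl (a 54-fold lower number from compound 1 to compound 3 (1.73 log units; beyond the scatter)), both large. Phenoxy and benzoyl themselves stay within the scatter (a 1.8-fold lower number from compound 2 to compound 3 (0.26 log units; within the scatter)). A large step to a lower number is therefore expected in this assay (a 24-fold lower number from compound 1 to compound 4 (1.38 log units; beyond the scatter)). Ethoxycarbonyl has no ring, unlike phenoxy and benzoyl, so the expected range stays wide on the upper side. Compound 4 is estimated at 45000 nM with a range from 12000 nM to 250000 nM as its expected span.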

Compound 4, concentration lethal to 50% of the cells: 123000 nM
Compound 4: middle estimate off by 2.7-fold (0.44 log units), on the low side, and the stated range covers the measured number.
By their numbers in this assay, from the lowest: compounds 3 and 2 (each within the scatter of the next); then compound 4; then compound 1.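

In this assay, ethoxycarbonyl, which has no ring, gives only a modest step at this position (an 8.8-fold lower number from compound 1 to compound 4 (0.94 log units; beyond the scatter)), whereas phenoxy and benzoyl both gave large ones. Compound 4 also stands apart from both ring-bearing compounds (a 6.2-fold higher number from compound 3 to compound 4 (0.79 log units; beyond the scatter); a 3.4-fold higher number from compound 2 to compound 4 (0.53 log units; beyond the scatter)), so replacements of hydroxymethyl here do not all reach one level, as compound 2 and compound 3 alone might have suggested. No measurement at hand accounts for these steps.

On these data alone, it remains open whether the ring or the carbonyl matters more. A carboxylic acid, an amine or a longer chain on the same aromatic carbon could help separate them.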